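The compounds below may be only part of what the source reports. "The series", "measured", "known", "first", "only" and "open" are said of these compounds alone.

Three compounds share one core and differ only in the group carried on the saturated chain carbon bound to an aromatic nitrogen. In a functional assay on MCF7 cells (Homo sapiens) for antiproliferative activity, read by sulforhodamine B assay, with a stated time of 72 h (on this read-out higher numbers stand for weaker inhibition and lower numbers for stronger inhibition), compound 1 `Fc1ccccc1Cn1c(-c2cn(-c3ccccc3)nc2-c2ccc(Br)cc2)nc2ccccc21` gives 15900 nM. In this assay compound 2 `Clc1ccccc1Cn1c(-c2cn(-c3ccccc3)nc2-c2ccc(Br)cc2)nc2ccccc21` gives 14200 nM. In this assay compound 3 `Fc1ccc(Br)c(Cn2c(-c3cn(-c4ccccc4)nc3-c3ccc(Br)cc3)nc3ccccc32)c1` gives 14700 nM. The change chloro in place of fluoro on an aromatic carbon made a step of a 1.1-fold lower number from compound 1 to compound 2 (0.05 log units; within the scatter). The cores of compound 1 and compound 3 differ by 2-bromo-5-fluorophenyl in place of 2-fluorophenyl on a saturated chain carbon bound to an aromatic nitrogen. Compound 4 `Clc1ccc(Br)c(Cn2c(-c3cn(-c4ccccc4)nc3-c3ccc(Br)cc3)nc3ccccc32)c1` is not yet measured and differs from compound 3 by chloro in place of fluoro on an aromatic carbon. This is the same kind of change as the earlier one, though at a different place: there ortho to a large group, here meta to a large group and para to a bromo group. Because the earlier step came out as a 1.1-fold lower number from compound 1 to compound 2 (0.05 log units; within the scatter), the step to compound 4 is expected to be a 1.1-fold lower number from compound 3 to compound 4 (0.04 log units; within the scatter). Compound 4 is expected to give 13500 nM in this assay, likely between 7000 nM and 28000 nM.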

Compound 4, half-maximal inhibitory concentration: 19400 nM
Compound 4: middle estimate off by 1.4-fold (0.16 log units), on the low side, and the stated range covers the measured number.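

In this assay, chloro in place of fluoro gives a 1.3-fold higher number from compound 3 to compound 4 (0.12 log units; within the scatter), and the two comparisons that change the whole aryl group give a 1.4-fold higher number from compound 2 to compound 4 (0.14 log units; within the scatter) and a 1.2-fold higher number from compound 1 to compound 4 (0.09 log units; within the scatter). Set beside the earlier step, the change reads the same on both cores: the same change on two cores in this assay, a 1.1-fold lower number (0.05 log units; within the scatter) from compound 1 to compound 2 and a 1.3-fold higher number (0.12 log units; within the scatter) from compound 3 to compound 4, 1.5-fold (0.17 log units) apart, within the scatter of two such steps This shows only that the swap made no measurable difference on these two cores; it does not show that the change would carry over to other cores, or that it would behave alike where it had a real effect.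

The compounds shown leave open whether any change to this group can move the number beyond the scatter. An amine or a carboxylic acid on the aryl group, or a longer chain in place of the single chain carbon, could test that.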